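The source may hold more compounds than are shown below. What is called first, only, known or untested is meant among the compounds shown, and "the series" means these compounds.

Working notes on the series, read in an ADME assay on MDBK cells (Bos taurus) for cytotoxicity; a higher number here means that more compound is tolerated, a lower number that less compound is tolerated. Compound 1 `Fc1cccc(F)c1-c1nc2ccn(Cc3ccccc3)cc-2n1` returns only a limit of the assay, > 100000 nM. Compound 2 `COc1ccccc1Cn1ccc2nc(-c3ccccc3)nc-2c1` likewise gives no number but the limit, > 100000 nM. Compound 3 `Fc1cccc(Cn2ccc3nc(-c4ccccc4)nc-3c2)c1` also stops at the limit, > 100000 nM. Compound 2 therefore stands where every value shown stands, at the ceiling of the measurement, with nothing beneath it to rank.

For the measured compounds named here, the one measured step, a step that the two limits leave unreadable from compound 2 to compound 3, runs between two limits and carries no readable size; it is the only step that resembles the change now in hand. Compound 4 `Brc1ccc(Cn2ccc3nc(-c4ccccc4)nc-3c2)cc1` differs from compound 2 as follows: 4-bromophenyl in place of 2-methoxyphenyl on a saturated chain carbon bound to an aromatic nitrogen. Among the values, the limit of > 100000 nM in this assay, at which 3 of the 3 values shown sit, is the whole of the guidance, and it shows no movement that could be read.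

The expected step is a step that the limit leaves unreadable from compound 2 to compound 4, none beyond the scatter. Compound 4 is expected to sit again at the limit, estimated at 150000 nM with a range from 60000 nM to 400000 nM.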

Compound 4, half-maximal cytotoxic concentration: 83000 nM
The estimate for compound 4 lay 1.8-fold (0.26 log units) above the measured number, and the stated range covers the measured number.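

In this assay, for the compounds shown here, compound 4 gives 83000 nM, the first actual number for a change on a saturated chain carbon bound to an aromatic nitrogen. This position is therefore no longer read from limits alone. The 4-bromophenyl change reads as an at least 1.2-fold lower number from compound 2 to compound 4 (0.08 log units; that floor lies within the scatter), and against the 3-fluorophenyl as an at least 1.2-fold lower number from compound 3 to compound 4 (0.08 log units; that floor lies within the scatter), so neither step establishes a real separation, and the step between the two limits still cannot be read. The series remains mostly at the ceiling of the measurement: the limit of > 100000 nM in this assay, at which 3 of the 4 values shown sit.

Going by these compounds, how far compound 2 and compound 3 actually lie from compound 4 stays open, as their values are limits and not numbers. Also open, on these data alone, is whether an amine or a carboxylic acid on this phenyl ring, or a longer chain in place of the single chain carbon, would give a step beyond the scatter.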